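Swapping an Aromatic Amide Partner for a Bicyclic One

The source may report more compounds than this note shows. Statements on the series, on what has been measured and on what is new or still open speak of the compounds shown alone.

Of the compounds shown here, three have so far been tested in an in vitro functional assay on HEK293-A cells for antagonist activity at metabotropic glutamate receptor 5 (Rattus norvegicus), read by calcium flux; a higher number here means a weaker inhibitor, a lower number a stronger inhibitor. For compound 1 `COc1ccccc1C(=O)Nc1cccc(NC(=O)C2CCCCC2)c1` the assay reports only its limit, > 30000 nM, and not a number. For compound 2 `COCC(=O)Nc1cccc(NC(=O)c2cccc(Cl)c2)c1` the same holds: the result is the limit > 30000 nM rather than a measured value. Compound 3 `O=C(Nc1cccc(Cl)c1)c1cccc(N2C(=O)c3ccccc3C2=O)c1` is the only one of the three to give an actual number, 1780 nM in this assay. It therefore stands alone among the values shown, while the other two results sit at the limit of > 30000 nM in this assay, at which 2 of the 3 values shown sit. No two of these compounds differ in a single place, so no measured step can be drawn between them.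

Compound 4 `O=C(NC1CC2CCC1C2)c1cccc(N2C(=O)c3ccccc3C2=O)c1` has not yet been tested. It differs from compound 3 in one place: a group of 7 heavy atoms (7 carbon; 2 five-membered non-aromatic rings of carbon only) in place of a group of 7 heavy atoms (6 carbon, 1 chlorine; one six-membered aromatic ring of carbon only), on an amide-type nitrogen. For the measured compounds named here, with no measured step of this kind to lean on, the size and direction of the change can only be estimated. Compound 4 is expected to be the weaker inhibitor, with an estimated step of a 6.7-fold higher number from compound 3 to compound 4 (0.83 log units; beyond the scatter) carrying it toward the limit of this assay. The estimate for compound 4 in this assay is 12000 nM, with a plausible range from 3000 nM to 30000 nM.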

Compound 4, half-maximal inhibitory concentration: > 30000 nM
Compound 4: only a limit was reported; the forecaster's own chance of this, stated with the estimate: 40%; middle value at least 2.5-fold (0.39 log units) from the limit.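

For the compounds shown here, this is the first measured step. With the shared core kept, placing the group with 2 five-membered non-aromatic rings of carbon only in the spot held by 3-chlorophenyl, on the amide-type nitrogen whose other neighbour is the carbonyl carbon, gives an at least 16-fold higher number from compound 3 to compound 4 (1.22 log units; beyond the scatter) in this assay. Both groups carry the same count of heavy atoms, and neither has hydrogen-bond donors or acceptors, so these counts do not separate them, yet the result at this position changes well beyond the scatter. The step is a bound and not an exact size, as compound 4 reached a limit of the assay and gave no number, which leaves compound 3 as the only compound with a measured value: the limit of > 30000 nM in this assay, at which 3 of the 4 values shown sit.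

The single change removes both the chlorine and the aromatic ring, and the compounds shown leave open which of the two matters; a plain phenyl group or a cyclohexyl group on the same nitrogen would pull them apart. From the compounds shown here alone, how a 3-methylphenyl group or a pyridine ring would fare at this position also remains open.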